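The source may report more compounds than this note shows. Statements on the series, on what has been measured and on what is new or still open speak of the compounds shown alone.

Compound 1 `CN1C/C(=C\c2cccnc2)C(=O)/C(=C/c2ccccc2F)C1` gives 4810 nM
Compound 2 `O=C1/C(=C/c2cccnc2)CN(S(=O)(=O)c2ccc(Cl)cc2)C/C1=C\c1ccccc1F` gives 12400 nM

Going by the values given here, in a functional assay on HepG2 cells (Homo sapiens) for cytotoxicity, read by MTT assay, with a stated time of 24 h (a higher number here means a weaker inhibitor, a lower number a stronger inhibitor), compound 2 holds the higher of the two numbers, and a 2.6-fold higher number from compound 1 to compound 2 (0.41 log units; beyond the scatter) is the only measured step. Compound 3 `O=C1/C(=C/c2cccnc2)CN(S(=O)(=O)c2ccc(Br)cc2)C/C1=C\c1ccccc1F` differs from compound 2 by bromo in place of chloro on an aromatic carbon with bromo in place of chloro on an aromatic carbon, para to a large group. Among the compounds with values here, the measured step brought in the whole (4-chlorophenyl)sulfonyl group, and no measured step exchanges one halogen for another. No change beyond the scatter is therefore expected. The expected result is a 1.1-fold lower number from compound 2 to compound 3 (0.03 log units; within the scatter) and no clear shift in either direction. Compound 3 is expected at 11500 nM with 6000 nM to 22000 nM as the estimated range.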

Compound 3, half-maximal inhibitory concentration: 8700 nM
Beside the measured number, compound 3's estimate is 1.3-fold (0.12 log units) above it, within the range that was stated.
By their numbers in this assay, from the lowest: compounds 1, 3 and 2 (each within the scatter of the next, the first and the last beyond it).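

In this assay, exchanging the halogen on this aromatic carbon, para to a large group, gives a step within the scatter (a 1.4-fold lower number from compound 2 to compound 3 (0.15 log units; within the scatter)), so chloro and bromo are not told apart here. Replacing methyl on the ring amine nitrogen with the sulfonyl group is beyond the scatter for the chloro partner (a 2.6-fold higher number from compound 1 to compound 2 (0.41 log units; beyond the scatter)) but within it for the bromo partner (a 1.8-fold higher number from compound 1 to compound 3 (0.26 log units; within the scatter)), so that separation does not hold for both halogens. No measurement given here accounts for either step. Going by these compounds, whether a methoxy group or an amine on this aromatic carbon would shift the number beyond the scatter remains open, as does the effect of an unsubstituted phenylsulfonyl group.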